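The source may hold more compounds than are shown below. What is called first, only, known or untested is meant among the compounds shown, and "the series" means these compounds.

Measured compounds:
Compound 1 `C=CC1=C(C(=O)Nc2ccccc2)C(c2ccc(Cl)c(Cl)c2)OC1` — in a functional assay on QGY7701 cells (Homo sapiens) for cytotoxicity, read by MTT assay, with a stated time of 24 h (on this read-out lower numbers stand for stronger inhibition and higher numbers for weaker inhibition), compound 1 gives > 100000 nM, a limit of the assay rather than a number.
Compound 2 `C=CC1=C(C(=O)Nc2cccc(C)c2)C(c2ccc(F)cc2)OC1` — in this assay compound 2 gives 56400 nM.
Compound 3 `C=CC1=C(C(=O)Nc2ccc(C)cc2)C(c2ccc(OC)cc2)OC1` — in this assay compound 3 gives > 100000 nM, again a limit and not a number.

Compound 1 thus stands at the limit of this assay, as shown by the limit of > 100000 nM in this assay, at which 2 of the 3 values shown sit, so its own figure is not known, only that it lies beyond the reported range. Within the data shown here, compound 2 is the only compound of the three with a number; it differs from compound 1 in more than one place, so the pair shows only that one sits at the limit and the other carries a value.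

Compound 4 `C=CC1=C(C(=O)Nc2ccccc2OC)C(c2ccc(Cl)c(Cl)c2)OC1` is the next compound in the series. It differs from compound 1 in a single place: methoxy in place of hydrogen on an aromatic carbon.

Among the measured compounds shown here, no pair differing in one place has been measured, so no measured step guides the expectation. Given that compound 1 gives > 100000 nM and compound 3 gives > 100000 nM, the expected step of an at least 1.1-fold lower number from compound 1 to compound 4 (0.04 log units; that floor lies within the scatter) is none beyond the scatter, with a fair chance that compound 4 again reports only a limit. Compound 4 is estimated at 90000 nM, within 30000 nM to 300000 nM.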

Compound 4, half-maximal inhibitory concentration: > 100000 nM
Compound 4: no number, only a limit; the forecaster's own chance of this, stated with the estimate: 55%; middle value at least 1.1-fold (0.04 log units) from the limit.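

Compound 1 and compound 4 both report only a limit in this assay, so no step can be read between them for methoxy in place of hydrogen: the limit of > 100000 nM in this assay, at which 3 of the 4 values shown sit. Going by these compounds, whether phenyl to 2-methoxyphenyl changes the read-out at all, and in which direction, stays open.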